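Adding a Methyl to the Ether Chain of Compound 1

The compounds below may be only part of what the source reports. "The series", "measured", "known", "first", "only" and "open" are said of these compounds alone.

Measured compounds:
- compound 1, `CCO[C@@]1(c2ccc(Cl)cc2)SC=C(C)n2c1noc2=O`, 270 nM
- compound 2, `CCCOC1(c2ccc(Br)cc2)SC=C(C)n2c1noc2=O`, 410 nM
- compound 3, `CCCCOC1(c2ccc(Br)cc2)SC=C(C)n2c1noc2=O`, 1020 nM

Of the compounds shown here, three have been tested in a functional assay (Cavia porcellus) with Rattus norvegicus as the target; a lower number here means that less compound is needed, a higher number that more compound is needed for the effect. In this assay compound 1 gives 270 nM, compound 2 gives 410 nM and compound 3 gives 1020 nM. The values of compound 1 and compound 2 lie within the scatter of each other, so no order between them can be read; the value of compound 3 stands further from that of compound 1.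

Compound 2 and compound 3 differ in one place: methyl in place of hydrogen on a saturated chain carbon, three bonds along the chain from an oxygen on a saturated carbon. This change made a 2.5-fold higher number from compound 2 to compound 3 (0.40 log units; beyond the scatter). The difference between the core of compound 1 and the core of compound 2 is not broken down here.

The unmeasured compound 4, `CC1=CS[C@@](OC(C)C)(c2ccc(Cl)cc2)c2noc(=O)n21`, arises from compound 1 by methyl in place of hydrogen on a saturated chain carbon bound to an oxygen on a saturated carbon and a saturated chain carbon. Going by the values given here, this is the same kind of change as the one from compound 2 to compound 3, but the place differs: in compound 4 the new methyl sits on a saturated chain carbon bound to an oxygen on a saturated carbon and a saturated chain carbon, whereas in compound 3 it sits three bonds along the chain from an oxygen on a saturated carbon.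

Among the compounds with values here, because the only measured example of this kind of change gave a 2.5-fold higher number from compound 2 to compound 3 (0.40 log units; beyond the scatter), a step of similar, modest size is expected here, with more room for uncertainty since the place is not the same. For compound 4 in this assay the expected step is a 2.0-fold higher number from compound 1 to compound 4 (0.31 log units; beyond the scatter). Compound 4 is therefore estimated at 550 nM, within a range from 250 nM to 1300 nM.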

Compound 4, half-maximal effective concentration: 220 nM
Compound 4: the middle estimate sits 2.5-fold (0.40 log units) above what was measured; the whole stated range lies above it.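

In this assay, turning ethoxy into isopropoxy gave a 1.2-fold lower number from compound 1 to compound 4 (0.09 log units; within the scatter), so on the core of compound 1 this added methyl produces no change that can be read. Set beside the earlier step, this shows that the size of a step seen on one core cannot simply be carried over to another, even when the change is of the same kind: the same change on two cores in this assay, a 2.5-fold higher number (0.40 log units; beyond the scatter) from compound 2 to compound 3 and a 1.2-fold lower number (0.09 log units; within the scatter) from compound 1 to compound 4, 3.1-fold (0.48 log units) apart, beyond the scatter of two such steps. What this does not show is the reason for the gap, since the two pairs differ both in their core and in where the new methyl sits, and with only these two pairs neither difference can be singled out, nor can any general rule for the series be drawn.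

The compounds shown leave open whether isopropoxy on the core of compound 2 would follow compound 4 or instead give a step more like the one seen when the chain grew to butoxy, and likewise how butoxy would behave on the core of compound 1. They also leave open how a bulkier tert-butoxy group, or a chain ending in an amine, would read in this assay on either core.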